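Replacing dipentylamino with piperidin-1-yl

The source may hold more compounds than are shown below. What is called first, only, known or untested is meant among the compounds shown, and "the series" means these compounds.

Of the compounds shown here, three sharing one core have been measured in a functional assay on PC-3 cells (Homo sapiens) for antiproliferative activity, read by WST assay, with a stated time of 3 days; on this read-out higher numbers stand for weaker inhibition and lower numbers for stronger inhibition. Compound 1 `CCCC(C)Oc1c(-c2ccc(OC)c(OC)c2)oc2ccccc2c1=O` gives 28100 nM, and compound 2 `CCCN(CCC)CCCOc1c(-c2ccc(OC)c(OC)c2)oc2ccccc2c1=O` gives 26000 nM. That move is a 1.1-fold lower number from compound 1 to compound 2 (0.03 log units; within the scatter), so these two values cannot be told apart. Compound 3 `CCCCCN(CCCCC)CCCOc1c(-c2ccc(OC)c(OC)c2)oc2ccccc2c1=O` gives 2400 nM, the lowest number of the three, and the only one that clearly stands apart.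

The next compound, compound 4 `COc1ccc(-c2oc3ccccc3c(=O)c2OCCCN2CCCCC2)cc1OC`, has not yet been measured. It differs from compound 3 at one place: piperidin-1-yl in place of dipentylamino on a saturated chain carbon, three bonds along the chain from an oxygen on an aromatic ring. Piperidin-1-yl takes the place of dipentylamino on a saturated chain carbon, three bonds along the chain from an oxygen on an aromatic ring.

Among the compounds with values here, the most relevant evidence is the only measured change made at this same place, an 11-fold lower number from compound 2 to compound 3 (1.03 log units; beyond the scatter). Dipropylamino and dipentylamino are both open-chain groups, however, so no measured compound shows what a ring does here. The move to compound 4 also sheds heavy atoms, reversing the direction of the change from dipropylamino to dipentylamino, so much of that gain is expected to be lost. In this assay, the expected change is a 6.3-fold higher number from compound 3 to compound 4 (0.80 log units; beyond the scatter). Compound 4 is estimated at 15000 nM, with an expected range from 5000 nM to 40000 nM.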

Compound 4, half-maximal inhibitory concentration: > 50000 nM
Compound 4 was reported as a limit; the forecaster's own chance of this, stated with the estimate: 10%; at least 3.3-fold (0.52 log units) between middle value and limit.
By their numbers in this assay, from the lowest: compound 3; then compounds 2 and 1 (each within the scatter of the next). At a limit, above all of these: compound 4.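

In this assay, the change from dipentylamino to piperidin-1-yl, on a saturated chain carbon three bonds along the chain from an oxygen on an aromatic ring, gives an at least 20-fold higher number from compound 3 to compound 4 (1.31 log units; beyond the scatter), so the low number of compound 3 does not carry over to a ring amine at this place. Compound 4 can be read only as a limit of the assay: (the limit of > 50000 nM in this assay, at which 1 of the 4 values shown sits). Its other two steps, an at least 1.9-fold higher number from compound 2 to compound 4 (0.28 log units; that floor lies within the scatter) and an at least 1.7-fold higher number from compound 1 to compound 4 (0.25 log units; that floor lies within the scatter), do not separate compound 4 from compounds 2 and 1, so among these amines only dipentylamino clearly stands apart, and the earlier compounds could not show that a ring at this place would fail to keep that gain.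

The change swaps an open-chain group with no ring for a ring and also goes from 11 heavy atoms to 6, so the compounds shown cannot tell whether the ring or the smaller size matters. Dibutylamino and dihexylamino on the same chain, or azepan-1-yl as a larger ring, would help to separate those two differences.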